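Turning a saturated ring aromatic on the benzylic side chain

The source may hold more compounds than are shown below. What is called first, only, known or untested is meant among the compounds shown, and "the series" means these compounds.

Compound 2 `Cn1nc2c(=O)n(CC3(O)CCN(Cc4ccc(C5CCCO5)cc4Cl)CC3)cnc2c1-c1ccc(CN)cc1` gives 3820 nM in an assay on isolated protein for inhibition of ubiquitin carboxyl-terminal hydrolase 7 (Homo sapiens), with stated times of 30 min and 2 h (a lower number here means a stronger inhibitor, a higher number a weaker inhibitor), and stands highest of the three numbers at hand, beyond the scatter from both companions. Within the data shown here, compound 1 `Cn1nc2c(=O)n(CC3(O)CCN(Cc4ccc(-c5ccco5)cc4Cl)CC3)cnc2c1-c1ccc(CNC=O)cc1` gives 20.9 nM in this assay, and compound 3 `Cn1nc2c(=O)n(CC3(O)CCN(Cc4ccc(-c5ccco5)cc4Cl)CC3)cnc2c1-c1ccc(CNS(C)(=O)=O)cc1` gives 65.3 nM in the same assay; the only single-point step among them, a 3.1-fold higher number from compound 1 to compound 3 (0.49 log units; beyond the scatter), concerns the amine substituent and not the ring that is exchanged here. Compound 4 `Cn1nc2c(=O)n(CC3(O)CCN(Cc4ccc(-c5ccsc5Cl)cc4Cl)CC3)cnc2c1-c1ccc(CN)cc1` differs from compound 2 by 2-chlorothiophen-3-yl in place of oxolan-2-yl on an aromatic carbon. Among the measured compounds shown here, no measured pair isolates this change. Compound 1 and compound 3 differ from compound 2 in more than one place, so their far lower numbers can only hint that the saturated ring of compound 2 is unfavourable. The step from compound 2 to compound 4 is therefore expected to be large and toward a lower number, a 15-fold lower number from compound 2 to compound 4 (1.18 log units; beyond the scatter), though with wide uncertainty. Compound 4 is estimated at 250 nM, in a range from 40 nM to 1500 nM.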

Compound 4, half-maximal inhibitory concentration: 453 nM
For compound 4 the middle estimate is 1.8-fold (0.26 log units) below the measured one; measured number inside the range.
By their numbers in this assay, from the lowest: compound 1; then compound 3; then compound 4; then compound 2.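

Exchanging the five-membered non-aromatic oxolan-2-yl for the five-membered aromatic 2-chlorothiophen-3-yl gives an 8.4-fold lower number from compound 2 to compound 4 (0.93 log units; beyond the scatter) in this assay and so shows, with the rest of the molecule held fixed, that this position para to a large group responds to the group it carries. The single step changes ring aromaticity, replaces oxygen with sulfur and adds a chlorine all at once, and it cannot be divided among these three differences. Nothing measured here speaks to the reason for the step.

The compounds shown leave open whether the chlorine on the thiophene matters, a question that a plain thiophen-3-yl would address. They also leave open how a phenyl ring or a saturated cyclopentyl ring would compare at this position with the rest of compound 2 unchanged.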